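Octadecyl chain with cinnamoyl cap: expected cytotoxicity

The source may report more compounds than this note shows. Statements on the series, on what has been measured and on what is new or still open speak of the compounds shown alone.

Measured so far in a functional assay on SiHa cells (Homo sapiens) for cytotoxicity, read by MTT assay, with a stated time of 48 h; on this read-out lower numbers stand for stronger inhibition and higher numbers for weaker inhibition:
compound 1 `CCCCCCCCNC(=O)[C@@H](NC(=O)/C=C/c1ccccc1)[C@@H](C)O` gives 41400 nM
compound 2 `CCCCCCCCCCCCCCCCCCNC(=O)[C@@H](NC(=O)c1cc2ccccc2o1)[C@@H](C)O` gives > 200000 nM

The value for compound 2 is a limit of this assay, not a number, and it sits at the limit of > 200000 nM in this assay, at which 1 of the 2 values shown sits. Compound 2 therefore stands at the weak end of the two values shown, whereas compound 1 gives a measured number. Compound 3 `CCCCCCCCCCCCCCCCCCNC(=O)[C@@H](NC(=O)/C=C/c1ccccc1)[C@@H](C)O` carries 2-phenylethenyl in place of 1-benzofuran-2-yl on a carbonyl carbon. Among the measured compounds shown here, no step between measured compounds differing in one place is available, so the size of this change can only be expected. Compound 1 shares the 2-phenylethenyl cap with compound 3 and differs from it in the chain, and the two values shown suggest the cap alone need not push the read-out to the limit. Compound 3 is estimated at 120000 nM, with a range of 30000 nM to 400000 nM. The expected step is an at least 1.6-fold lower number from compound 2 to compound 3 (0.22 log units; that floor lies within the scatter), towards stronger inhibition, though a limit again remains possible.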

Compound 3, half-maximal inhibitory concentration: 35900 nM
Beside the measured number, compound 3's estimate is 3.3-fold (0.52 log units) above it, within the range that was stated.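

Among the compounds shown here, at the carbonyl carbon, 2-phenylethenyl in place of 1-benzofuran-2-yl gives an at least 5.5-fold lower number from compound 2 to compound 3 (0.74 log units; beyond the scatter) in this assay, the first one-place reading of this cap position. The entry for compound 2 is a limit of this assay, not a number: the limit of > 200000 nM in this assay, at which 1 of the 3 values shown sits.

The chain change, decyl in place of hydrogen on a saturated chain carbon, gives a 1.2-fold lower number from compound 1 to compound 3 (0.06 log units; within the scatter), so with the 2-phenylethenyl cap the two chains are not told apart in this assay.

Still open, as far as these compounds go, is what the 1-benzofuran-2-yl cap gives on the shorter chain of compound 1, and so whether the cap step holds on both chains. Also open, from the compounds shown here alone, is how a pyridin-3-yl group on the same carbonyl carbon would read, set against 2-phenylethenyl on either chain.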